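The source may hold more compounds than are shown below. What is called first, only, known or untested is meant among the compounds shown, and "the series" means these compounds.

Measured compounds:
- compound 1, `COc1cccc(CNCCCNc2ccnc3cc(Oc4ccc(Cl)cc4)ccc23)c1O`, gives 14500 nM in a physicochemical assay for solubility, with a stated time of 18 h, at pH 7.4; on this read-out lower numbers stand for lower solubility and higher numbers for higher solubility
- compound 2, `COc1cccc(CNCCCNc2ccnc3cc(Cc4ccccc4)ccc23)c1O`, gives 4200 nM in this assay
- compound 3, `COc1cccc(CNCCCNc2ccnc3cc(Oc4ccc(F)cc4)ccc23)c1O`, gives 14500 nM in this assay

All three share one core and differ only in the group attached to an aromatic carbon of that core. Compound 3 stands level with compound 1, the two together giving the highest numbers of the set, while compound 2 sits clearly lower: a 3.5-fold higher number from compound 2 to compound 3 (0.54 log units; beyond the scatter). The swap of chloro for fluoro left the read-out unchanged (no change at the digits printed from compound 1 to compound 3 (within the scatter)), so the type of group at this position, rather than the halogen on it, is what moved the number.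

Compound 4, `COc1cccc(CNCCCNc2ccnc3cc(CCC(C)C)ccc23)c1O`, is not yet measured. It differs from compound 3 in one place: isopentyl in place of 4-fluorophenoxy on an aromatic carbon. Among the measured compounds shown here, the only step that bears on such a change is the one where benzyl took the place of an aryloxy group, a 3.5-fold lower number from compound 1 to compound 2 (0.54 log units; beyond the scatter), and its reverse, a 3.5-fold higher number from compound 2 to compound 3 (0.54 log units; beyond the scatter). Isopentyl, like benzyl, brings no hydrogen-bond acceptor, and it also brings no ring, so a step downward of at least that size is expected for compound 4, a 3.6-fold lower number from compound 3 to compound 4 (0.56 log units; beyond the scatter). The estimate for compound 4 is therefore 4000 nM, with a likely range from 1200 nM to 13000 nM.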

Compound 4, solubility: 4200 nM
Compound 4: middle estimate off by 1.1-fold (0.02 log units), on the low side, within the range that was stated.
By their numbers in this assay, from the lowest: compounds 2 and 4 (each within the scatter of the next); then compounds 1 and 3 (each within the scatter of the next).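

In this assay, the step from compound 2 to compound 4 shows that a ring at the end of the group is not what sets the lower level: swapping the phenyl of the benzyl group for isobutyl gives no change at the digits printed from compound 2 to compound 4 (within the scatter) and leaves the read-out where it was. Compared directly with the isopentyl group, the fluorinated aryloxy group gives a 3.5-fold lower number from compound 3 to compound 4 (0.54 log units; beyond the scatter) and the chlorinated one gives a 3.5-fold lower number from compound 1 to compound 4 (0.54 log units; beyond the scatter), so the two halogens again behave alike, and among these four compounds the groups joined through oxygen sit at the higher level while the two joined through carbon sit at the lower one, with no compound going against this split. Nothing available here explains why these two kinds of group separate in this way.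

As far as these compounds go, what remains open is whether the oxygen link alone carries the higher level, which a chain joined through oxygen, such as isopentyloxy, would test against isopentyl. From the compounds shown here alone, how an amine, a carboxylic acid or a longer chain would read at this aromatic carbon also remains unknown from these compounds.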